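The source may report more compounds than this note shows. Statements on the series, on what has been measured and on what is new or still open speak of the compounds shown alone.

Measured so far:
compound 1, `CN(C)c1ccc(C(=O)N(CCCCCC(=O)NO)CC(=O)NC2CCCCC2)cc1`: 1540 nM
compound 2, `CC(C)(C(=O)NC1CCCCC1)N(CCCCCC(=O)NO)C(=O)c1ccccc1`: 295000 nM
compound 3, `CC(C)(C)NC(=O)C(C)(C)N(CCCCCC(=O)NO)C(=O)c1ccccc1`: 207000 nM

In a functional assay on A2780 cells (Homo sapiens) for cytotoxicity, read by MTT assay, with a stated time of 72 h (on this read-out higher numbers stand for weaker inhibition and lower numbers for stronger inhibition), compound 1 gives the lowest of these three numbers, and compound 2 and compound 3 sit far higher. Compound 1 and compound 2 are built on different cores, and the difference between the two cores is not broken down here. Compound 2 and compound 3 differ by tert-butyl in place of cyclohexyl on an amide-type nitrogen, which gave a 1.4-fold lower number from compound 2 to compound 3 (0.15 log units; within the scatter). The unmeasured compound 4, `CN(C)c1ccc(C(=O)N(CCCCCC(=O)NO)CC(=O)NC(C)(C)C)cc1`, differs from compound 1 by the same change, (tert-butyl in place of cyclohexyl on an amide-type nitrogen), at a place described in the same words. Because the earlier change gave a 1.4-fold lower number from compound 2 to compound 3 (0.15 log units; within the scatter), a change within the scatter, only a small step is expected here as well, a 1.0-fold higher number from compound 1 to compound 4 (0.02 log units; within the scatter). Compound 4 is accordingly expected to give about 1600 nM, most likely between 600 nM and 4500 nM.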

Compound 4, half-maximal inhibitory concentration: 1030 nM
Estimate against measurement, compound 4: 1.6-fold (0.19 log units) above, within the range that was stated.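

In this assay, putting tert-butyl in place of cyclohexyl on the amide-type nitrogen gave a 1.5-fold lower number from compound 1 to compound 4 (0.17 log units; within the scatter). The change behaved alike on the two cores, and the two steps match: the same change on two cores in this assay, a 1.4-fold lower number (0.15 log units; within the scatter) from compound 2 to compound 3 and a 1.5-fold lower number (0.17 log units; within the scatter) from compound 1 to compound 4, 1.0-fold (0.02 log units) apart, within the scatter of two such steps. This shows that the change stays small on both cores, but both steps lie within the scatter, so it does not show that either group is better, nor that a third core would behave the same way.

The compounds shown leave open whether a different group on that nitrogen, such as methyl or phenyl, would shift the number beyond the scatter. They also leave open what a longer chain leading to the hydroxamic acid would do.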